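The source may report more compounds than this note shows. Statements on the series, on what has been measured and on what is new or still open speak of the compounds shown alone.

In a functional assay (Homo sapiens) for inhibition (on this read-out higher numbers stand for weaker inhibition and lower numbers for stronger inhibition), compound 1 `CS(=O)(=O)c1ccc(CSc2nc(-c3ccc(F)cc3)c(-c3ccncc3)[nH]2)cc1` gives 330 nM and compound 2 `Fc1ccc(-c2[nH]c(SCc3ccccc3)nc2-c2ccncc2)cc1` gives 300 nM. These two values lie within the usual scatter of each other, so compound 2 cannot be ranked apart from compound 1.

Compound 3 `Fc1ccc(-c2[nH]c(SCCc3ccccc3)nc2-c2ccncc2)cc1` has not yet been measured. It differs from compound 2 by a single change, benzyl in place of phenyl on a saturated chain carbon bound to a sulfur. This lengthens benzylsulfanyl to phenethylsulfanyl.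

Going by the values given here, no measured pair shows this change, so the data offer no direct guide to it. Compound 1 and compound 2 differ in structure yet show values within the scatter, so no step beyond the scatter is expected in this assay, and no direction is favoured. The expected change is no change at the digits printed from compound 2 to compound 3 (within the scatter). Compound 3 is expected near 300 nM, with an estimated range of 100 nM to 900 nM.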

Compound 3, half-maximal inhibitory concentration: 640 nM
Compound 3: the middle estimate sits 2.1-fold (0.33 log units) below what was measured; measured number inside the range.
By their numbers in this assay, from the lowest: compounds 2, 1 and 3 (each within the scatter of the next, the first and the last beyond it).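

In this assay, going by these compounds alone, lengthening benzylsulfanyl to phenethylsulfanyl gives a 2.1-fold higher number from compound 2 to compound 3 (0.33 log units; beyond the scatter) and so provides the first readable step at this position. The length of the chain that links the sulfur to the phenyl ring therefore matters here, if only modestly, and the shorter benzylsulfanyl of compound 2 gives the stronger inhibition of this pair. Nothing available here explains why the longer chain gives weaker inhibition.

A single added carbon cannot show whether the number keeps rising with a still longer chain, such as phenylpropylsulfanyl, or how a shorter group, such as methylsulfanyl, would compare. Going by these compounds, it also remains open whether an amine or a carboxylic acid at the end of the chain, in place of the phenyl ring, would be tolerated.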